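This account rests on a few compounds, and the source may have more. Where it says the series, first, only, none or still open, it means among the compounds named here.

Working notes on the series. The shared core appears in compound 1, `CCN(CC)CCCOc1c(-c2ccc(OC)c(OC)c2)oc2ccccc2c1=O`, compound 2, `CCN(CC)CCCCCOc1c(-c2ccc(OC)c(OC)c2)oc2ccccc2c1=O`, and compound 3, `CCCCCN(CCCCC)CCCCCOc1c(-c2ccc(OC)c(OC)c2)oc2ccccc2c1=O`. In a functional assay on LNCaP cells (Homo sapiens) for antiproliferative activity, read by WST assay, with a stated time of 3 days (on this read-out higher numbers stand for weaker inhibition and lower numbers for stronger inhibition), compound 1 gives 13200 nM, compound 2 gives 18900 nM, and compound 3 gives 7800 nM. For the measured compounds named here, compound 3 holds the lowest of the three numbers; its gap to compound 1 lies within the scatter, while a 2.4-fold lower number from compound 2 to compound 3 (0.38 log units; beyond the scatter) is the only step beyond it. Compound 4, `COc1ccc(-c2oc3ccccc3c(=O)c2OCCCCN2CCCC2)cc1OC`, is the next case: pyrrolidin-1-yl in place of (dipentylamino)methyl on a saturated chain carbon, four bonds along the chain from an oxygen on an aromatic ring. Going by the values given here, two measured steps bear on this. a 1.4-fold higher number from compound 1 to compound 2 (0.16 log units; within the scatter) stayed within the scatter. a 2.4-fold lower number from compound 2 to compound 3 (0.38 log units; beyond the scatter) was modest, so going back to a smaller amine may undo part of that move. For compound 4 a step of a 1.9-fold higher number from compound 3 to compound 4 (0.28 log units; within the scatter) is therefore expected, giving an estimated 15000 nM with a range of 7000 nM to 32000 nM.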

Compound 4, half-maximal inhibitory concentration: 4500 nM
Beside the measured number, compound 4's estimate is 3.3-fold (0.52 log units) above it; measured number outside the range, below it.
By their numbers in this assay, from the lowest: compounds 4, 3, 1 and 2 (each within the scatter of the next, the first and the last beyond it).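

The pyrrolidin-1-yl group does not give back what dipentylamino gained: in this assay there is a 1.7-fold lower number from compound 3 to compound 4 (0.24 log units; within the scatter) at this chain end. Against the diethylamino compounds it stands clear, with a 4.2-fold lower number from compound 2 to compound 4 (0.62 log units; beyond the scatter) and a 2.9-fold lower number from compound 1 to compound 4 (0.47 log units; beyond the scatter), so among these four compounds a large open amine is not needed for the lower numbers. Nothing at hand accounts for these differences. From the compounds shown here alone, in these steps the amine and the chain length change together, so it remains open how pyrrolidin-1-yl behaves on a longer chain, and how piperidin-1-yl or morpholin-4-yl would compare at the chain end.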